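The source may report more compounds than this note shows. Statements on the series, on what has been measured and on what is new or still open speak of the compounds shown alone.

In an ADME assay on RAW264.7 cells (Mus musculus) for cytotoxicity, read by trypan blue exclusion, with a stated time of 48 h (a lower number here means a stronger inhibitor of growth, a higher number a weaker inhibitor of growth), compound 2 `Cc1cc(CN2CCN(c3ccccc3)CC2)c(C)n1-c1ccc(Cl)cc1` gives 33 ug/mL and stands second highest of three numbers on this scale. Compound 1 `Cc1cc(CN2CCN(C3C[C@@H]4CC[C@H]3C4)CC2)c(C)n1-c1ccc(Cl)cc1` gives 5.6 ug/mL, and compound 3 `Cc1cc(CNOCc2ccccc2)c(C)n1-c1ccc(F)cc1` gives 123 ug/mL. Compound 4 `Cc1cc(CN2CCN(C3CCCCC3)CC2)c(C)n1-c1ccc(Cl)cc1` has cyclohexyl in place of phenyl on an amine nitrogen in a ring. Among the measured compounds shown here, the one measured step that bears on this change is a 5.9-fold higher number from compound 1 to compound 2 (0.77 log units; beyond the scatter) as phenyl replaced a non-aromatic group of carbon rings. Cyclohexyl also leaves a non-aromatic ring of carbon only, so a modest move to a lower number is expected, though one step is thin evidence. The expected move is an estimated 3.7-fold lower number from compound 2 to compound 4 (0.56 log units; beyond the scatter) in this assay. For compound 4 the estimate is 9 ug/mL with an expected range from 3.5 ug/mL to 22 ug/mL (estimated).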

Compound 4, concentration for 50% growth inhibition: 5.5 ug/mL
Compound 4: the middle estimate sits 1.6-fold (0.21 log units) above what was measured; low and high end bracket the measured number.
By their numbers in this assay, from the lowest: compounds 4 and 1 (each within the scatter of the next); then compound 2; then compound 3.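

In this assay cyclohexyl in place of phenyl gives a 6.0-fold lower number from compound 2 to compound 4 (0.78 log units; beyond the scatter) at the same place, a direct comparison of a non-aromatic with an aromatic six-membered ring of carbon only. The one-ring and two-ring non-aromatic groups cannot be told apart, with a 1.0-fold lower number from compound 1 to compound 4 (0.01 log units; within the scatter) in this assay, so compound 2 stands apart from both compound 1 and compound 4. The data shown offer no explanation for this step.

Still open, as far as these compounds go, is whether a piperidine ring or a longer alkyl chain on this amine nitrogen would give a number closer to that of compound 4 or that of compound 2.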